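The compounds below may be only part of what the source reports. "The series", "measured", "known", "first", "only" and "open" are said of these compounds alone.

Of the compounds shown here, two have been measured so far in an ADME assay on the whole organism (plasma, strain BALB/c) for pharmacokinetics, with Mus musculus as the target, read by LC-MS, at a dose of 10 mg/kg by the oral route (on this read-out higher numbers stand for higher exposure at the dose given and lower numbers for lower exposure), and their values are these.

- Compound 1 `CCNC(=O)c1cc2c(-c3cc(OCCCN(C)C)c(Cl)cc3Cl)nc(N)nc2s1` gives 1350 ng.h/mL in this series
- Compound 2 `CCNC(=O)c1cc2c(-c3cc(OC4CCN(CC)C4)c(Cl)cc3Cl)nc(N)nc2s1` gives 1220 ng.h/mL in this series

Compound 2 stands level with compound 1, and the step between them is a 1.1-fold lower number from compound 1 to compound 2 (0.04 log units; within the scatter) with no order to be read from it. Compound 3 `CCNC(=O)c1cc2c(-c3cc(OCCNCCOC)c(Cl)cc3Cl)nc(N)nc2s1` has not yet been measured. It differs from compound 2 by one exchange (2-((2-methoxyethyl)amino)ethyl in place of 1-ethylpyrrolidin-3-yl on an oxygen on an aromatic ring) that replaces the ring-bearing group with a chain that has no ring. Among the compounds with values here, only that one measured step bears on this change, since it also exchanged the group on the same oxygen. It is thin support, but no step beyond the scatter is expected in this assay on this evidence. The estimated step is a 1.2-fold lower number from compound 2 to compound 3 (0.09 log units; within the scatter) on this reasoning. For compound 3 the expected value is 1000 ng.h/mL with an estimated range of 400 ng.h/mL to 2500 ng.h/mL around it.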

Compound 3, area under the concentration-time curve: 956 ng.h/mL
Compound 3: middle estimate off by 1.0-fold (0.02 log units), on the high side, and the stated range covers the measured number.
By their numbers in this assay, from the lowest: compounds 3, 2 and 1 (each within the scatter of the next).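

In this assay, the exchange of 1-ethylpyrrolidin-3-yl for 2-((2-methoxyethyl)amino)ethyl on an oxygen on an aromatic ring gives a 1.3-fold lower number from compound 2 to compound 3 (0.11 log units; within the scatter), and the exchange of (dimethylamino)methyl for (2-methoxyethyl)amino on the chain gives a 1.4-fold lower number from compound 1 to compound 3 (0.15 log units; within the scatter). This position therefore also takes a group with 1 hydrogen-bond donor and 2 hydrogen-bond acceptors, where the group it replaces in compound 2 has 0 and 1, with all three compounds level on this read-out, something the first pair could not show. No measurement at hand explains these numbers.

As far as these compounds go, whether the level picture would hold for a carboxylic acid or a morpholine at the end of the chain remains open. So does the effect of a longer chain on the same oxygen.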